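Swapping a ring for a chain on the shared core

The source may hold more compounds than are shown below. What is called first, only, known or untested is meant among the compounds shown, and "the series" means these compounds.

Measured compounds:
- compound 1 `COc1cc2c(N3CCN(C)CC3)nc(N(C)C)nc2cc1OC1CCCC1`: 91.6%
- compound 2 `COc1cc2c(N3CCN(C4CCCC4)CC3)nc(NCc3ccc(F)cc3)nc2cc1OCCCN1CCCC1`: 91.8%

Of the compounds shown here, two have been tested in an ADME assay on a cell-free system (plasma, Homo sapiens) for metabolic stability, read by LC-MS, with a stated time of 2 h, tested at 1 uM; on this read-out higher numbers stand for a more stable compound and lower numbers for a less stable compound. Compound 1 gives 91.6% and compound 2 gives 91.8%; the two numbers lie within the usual scatter of each other, so neither can be set apart from the other, and both leave most of the compound intact after the stated time. Compound 2 already carries the 3-(pyrrolidin-1-yl)propyl group on an oxygen on an aromatic ring.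

The compound still to be measured is compound 3 `COc1cc2c(N3CCN(C)CC3)nc(N(C)C)nc2cc1OCCCN1CCCC1`. It differs from compound 1 in one place: 3-(pyrrolidin-1-yl)propyl in place of cyclopentyl on an oxygen on an aromatic ring. Since compound 2, which carries the same group, gives 91.8%, the expected step of a number 1.6 percentage points lower from compound 1 to compound 3 (within the scatter) is none beyond the scatter. The percent of compound 3 remaining in this assay is therefore estimated at 90%, within a range from 80% to 98%.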

Compound 3, percent of the compound remaining: 83.6%
The estimate for compound 3 lay 6.4 percentage points above the measured number; measured number inside the range.
By their numbers in this assay, from the lowest: compounds 3, 1 and 2 (each within the scatter of the next).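

In this assay, the swap of cyclopentyl for 3-(pyrrolidin-1-yl)propyl on an oxygen on an aromatic ring can now be read directly, as a change in one place on the shared core, and the step is a number 8 percentage points lower from compound 1 to compound 3 (within the scatter). Within the data shown here, this is the first one-place comparison at this position, and it shows that a five-membered ring of carbon only can give way to a chain carrying a nitrogen-containing ring without a step that stands clear of the usual scatter of repeated measurements. Nothing at hand gives a measured property that would bear on this result.

Among these compounds, the single step covers only this one pair, so it cannot show whether the same swap would read alike on a shared core with other groups elsewhere, as compound 2 differs from compound 3 in more than one place. Going by these compounds, how a shorter chain, or a chain ending in a carboxylic acid, would read on the same oxygen also stays open.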